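From methoxy to hydroxy in a growth inhibitor

This account rests on a few compounds, and the source may have more. Where it says the series, first, only, none or still open, it means among the compounds named here.

Measured in a functional assay on cells (Leukemia cell, Homo sapiens) for cytotoxicity, read by sulforhodamine B assay, with a stated time of 48 h (a lower number here means a stronger inhibitor of growth, a higher number a weaker inhibitor of growth), so far:
compound 1 `COc1ccc2c(c1)/C(=C/c1c(-c3ccncc3)nc3sccn13)C(=O)N2C` gives 350 nM
compound 2 `COc1nc2sc(C)cn2c1C=C1C(=O)N(C)c2ccccc21` gives 4350 nM
compound 3 `COc1ccc2c(c1)/C(=C\c1c(OC)nc3sc(C)cn13)C(=O)N2` gives 430 nM

Compound 3 and compound 1 lie within the usual scatter of each other, so these numbers do not separate them. Compound 2 has a much higher number, and its gap to compound 3 is beyond the scatter, which makes compound 2 the weaker inhibitor of growth of that pair.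

The next compound to be tested is compound 4 `COc1nc2sc(C)cn2c1/C=C1/C(=O)Nc2ccc(O)cc21` and it differs from compound 3 in one place only (hydrogen in place of methyl on an oxygen on an aromatic ring), with hydrogen in place of methyl on an oxygen on an aromatic ring. The same difference reads as methoxy to hydroxy.

Within the data shown here, no two measured compounds show this change on its own, so the data offer no direct guide to its size. The starting point is therefore compound 3 at 430 nM and the range must stay wide. The expected step of a 1.5-fold higher number from compound 3 to compound 4 (0.18 log units; within the scatter) is small, towards a somewhat higher number, and may well stay within the scatter. For compound 4 the estimated value is 650 nM (170 nM to 2500 nM).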

Compound 4, concentration for 50% growth inhibition: 3320 nM
Compound 4: middle estimate off by 5.1-fold (0.71 log units), on the low side, and the stated range ends below it.
By their numbers in this assay, from the lowest: compounds 1 and 3 (each within the scatter of the next); then compounds 4 and 2 (each within the scatter of the next).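

In this assay, replacing methoxy with hydroxy on the aromatic ring is not a neutral exchange: the step is a 7.7-fold higher number from compound 3 to compound 4 (0.89 log units; beyond the scatter) and so lies well outside ordinary repeat variation. Among these compounds, this is the first direct reading of this position, as no earlier pair of compounds differed here alone, and it shows that losing a single methyl carbon from this oxygen can sharply weaken growth inhibition. Nothing available explains the size of this step, so it stands as an observation without a known cause.

As far as these compounds go, it remains open whether the methyl group itself is what counts or whether any group on this oxygen would serve, which an ethyl group or a longer chain on the same oxygen, or an amine or a fluorine atom in place of the methoxy group, could help to settle. Among the compounds shown here, only this one pair shows the change, so it is also open whether a step of similar size would appear with different groups elsewhere on the shared core.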